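The source may report more compounds than this note shows. Statements on the series, on what has been measured and on what is new or still open speak of the compounds shown alone.

Three compounds share one core and differ only in a single group on the outer aromatic ring. In a functional assay on RCC4 cells (Homo sapiens) for inhibition, read by XTT assay, with a stated time of 4 days (on this read-out lower numbers stand for stronger inhibition and higher numbers for weaker inhibition), compound 1 `CC(C)c1cccc(Nc2nc(-c3ccncc3)cs2)c1` gives 17400 nM. Compound 2 `Oc1cccc(Nc2nc(-c3ccncc3)cs2)c1` gives 28800 nM in this assay, and compound 3 `Brc1cccc(Nc2nc(-c3ccncc3)cs2)c1` gives 40700 nM in this assay, the highest of the three numbers. The step of a 2.3-fold higher number from compound 1 to compound 3 (0.37 log units; beyond the scatter) is the only one beyond the scatter, whereas a 1.4-fold higher number from compound 2 to compound 3 (0.15 log units; within the scatter) stays within it. Compound 4 `CC(C)(C)c1cccc(Nc2nc(-c3ccncc3)cs2)c1` differs from compound 3 by tert-butyl in place of bromo on an aromatic carbon. Because a 2.3-fold higher number from compound 1 to compound 3 (0.37 log units; beyond the scatter) went in the opposite direction when bromo entered in place of isopropyl, and tert-butyl is again a branched alkyl group, the step of a 2.5-fold lower number from compound 3 to compound 4 (0.41 log units; beyond the scatter) is expected to bring the number down by a modest amount. Compound 4 is therefore estimated at 16000 nM in this assay, with a range from 6000 nM to 42000 nM.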

Compound 4, half-maximal inhibitory concentration: 60300 nM
For compound 4 the middle estimate is 3.8-fold (0.58 log units) below the measured one; the measured number lies above the stated range.
By their numbers in this assay, from the lowest: compounds 1, 2, 3 and 4 (each within the scatter of the next, the first and the last beyond it).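

In this assay tert-butyl in place of bromo cannot be told apart from bromo at this position (a 1.5-fold higher number from compound 3 to compound 4 (0.17 log units; within the scatter)). Against hydroxy, tert-butyl does stand apart (a 2.1-fold higher number from compound 2 to compound 4 (0.32 log units; beyond the scatter)), and so it does against isopropyl, from which it differs by one methyl (a 3.5-fold higher number from compound 1 to compound 4 (0.54 log units; beyond the scatter)), so branched alkyl groups at this position do not share one level. No measurement offered here explains these steps. The compounds shown leave open how an amine or a carboxylic acid on this carbon would read, and whether any group here can bring the number much lower than in compound 1.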